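This account rests on a few compounds, and the source may have more. Where it says the series, first, only, none or still open, it means among the compounds named here.

Compound 1 `Oc1ccc(-c2cc(-c3cccs3)cc(-c3ccccc3O)n2)cc1` is tested in a functional assay on HeLa cells (Homo sapiens) for cytotoxicity, read by CCK-8 assay (a higher number here means a weaker inhibitor, a lower number a stronger inhibitor), and returns only a limit, > 50000 nM. Compound 2 `Oc1ccc(-c2cc(-c3cccs3)cc(-c3cccc(O)c3)n2)cc1` gives a number in this assay, 4140 nM. The change between them is 3-hydroxyphenyl in place of 2-hydroxyphenyl on an aromatic carbon, and the step is an at least 12-fold lower number from compound 1 to compound 2 (1.08 log units; beyond the scatter); its size can only be given as a bound because compound 1 sits at the limit of > 50000 nM in this assay, at which 2 of the 3 values shown sit. Compound 3 `Oc1ccccc1-c1cc(-c2ccco2)cc(-c2ccccc2O)n1` also returns only a limit in this assay, > 50000 nM. How the core of compound 3 differs from that of compound 1 is not broken down here. Compound 4 `Oc1cccc(-c2cc(-c3ccco3)cc(-c3ccccc3O)n2)c1` arises from compound 3 by 3-hydroxyphenyl in place of 2-hydroxyphenyl on an aromatic carbon, the same kind of change as from compound 1 to compound 2, though here it sits meta to a 2-hydroxyphenyl group and meta to a furan-2-yl group rather than meta to a 4-hydroxyphenyl group and a thiophen-2-yl group. Resting on the step from compound 1 to compound 2, an at least 12-fold lower number from compound 1 to compound 2 (1.08 log units; beyond the scatter), the estimated step in this assay is an at least 8.3-fold lower number from compound 3 to compound 4 (0.92 log units; beyond the scatter). Compound 4 is therefore expected to give about 6000 nM in this assay, between 2000 nM and 40000 nM.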

Compound 4, half-maximal inhibitory concentration: > 50000 nM
Compound 4: no number, only a limit (the forecaster's own chance of this, stated with the estimate: 25%); at least 8.3-fold (0.92 log units) between middle value and limit.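

Compound 4 returns only a limit in this assay, > 50000 nM. Compound 3 also gives only a limit, so no step from compound 3 to compound 4 can be read: the limit of > 50000 nM in this assay, at which 3 of the 4 values shown sit.

The compounds shown leave open whether 3-hydroxyphenyl in place of 2-hydroxyphenyl changes the number at all alongside a furan-2-yl group.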